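The source may hold more compounds than are shown below. What is called first, only, known or untested is meant among the compounds shown, and "the series" means these compounds.

Measured compounds:
Compound 1 `CC1=C(C(=O)Nc2ccc(Br)cc2)C(c2ccc(Cl)cc2Cl)N=C(SCc2ccccc2Cl)N1` gives 20.6%.
Compound 2 `CC1=C(C(=O)Nc2ccc(Br)cc2)C(c2ccc(Cl)cc2Cl)N=C(SCc2cccc(Cl)c2)N1` gives 11.3%.
Compound 3 `COc1ccc(C2N=C(SCc3ccccc3Cl)NC(C)=C2C(=O)Nc2ccc(Br)cc2)cc1` gives 10.8%.

All three were tested in a functional assay on the whole organism (artery, strain albino) with Rattus norvegicus as the target, with a stated time of 720 min, at a dose of 10 mg/kg by the oral route; a lower number here means less inhibition, a higher number more inhibition at the dose given (going by the name of the read-out). Compound 1 and compound 2 share a core and differ in one place: 3-chlorophenyl in place of 2-chlorophenyl on a saturated chain carbon bound to a sulfur. That change produced a number 9.3 percentage points lower from compound 1 to compound 2 (within the scatter). Compound 3 carries the core of compound 1 with a different group on the ring: 4-methoxyphenyl in place of 2,4-dichlorophenyl on a saturated ring carbon. That change produced a number 9.8 percentage points lower from compound 1 to compound 3 (within the scatter). All three values lie within the usual scatter of one another, so no ordering among them can be claimed from these numbers.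

Compound 4 `COc1ccc(C2N=C(SCc3cccc(Cl)c3)NC(C)=C2C(=O)Nc2ccc(Br)cc2)cc1` has not yet been measured. It is built from compound 3 by the same change that turned compound 1 into compound 2: 3-chlorophenyl in place of 2-chlorophenyl on a saturated chain carbon bound to a sulfur. The place of the change is the same in both pairs, so this is the same change, applied to a different core. For the measured compounds named here, the one measured instance moved the number down but stayed inside the scatter, and nothing in the data suggests the second core would behave differently. For compound 4 the expected step is therefore small, a number 5.8 percentage points lower from compound 3 to compound 4 (within the scatter). Going by the values given here, this rests on the single measured instance, a number 9.3 percentage points lower from compound 1 to compound 2 (within the scatter). In this assay compound 4 is estimated at 5%, most likely between -6% and 18%.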

Compound 4, a percentage reported as inhibition, in the whole organism at one dose (the size of the read-out at that dose, not a potency): 26.8%
Beside the measured number, compound 4's estimate is 21.8 percentage points below it, outside the stated range (above it).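

In this assay, the change from (2-chlorobenzyl)sulfanyl to (3-chlorobenzyl)sulfanyl gives a number 16 percentage points higher from compound 3 to compound 4 (beyond the scatter), and this step on the core carrying 4-methoxyphenyl does not match the one seen on the core carrying 2,4-dichlorophenyl: the same change on two cores in this assay, a number 9.3 percentage points lower (within the scatter) from compound 1 to compound 2 and a number 16 percentage points higher (beyond the scatter) from compound 3 to compound 4, 25.3 percentage points apart, beyond the scatter of two such steps

Read the other way round, 4-methoxyphenyl in place of 2,4-dichlorophenyl gives a number 15.5 percentage points higher from compound 2 to compound 4 (beyond the scatter), and this too depends on which chlorobenzyl group is present: the same change on two cores in this assay, a number 9.8 percentage points lower (within the scatter) from compound 1 to compound 3 and a number 15.5 percentage points higher (beyond the scatter) from compound 2 to compound 4, 25.3 percentage points apart, beyond the scatter of two such steps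

So in these four compounds the two changes do not act independently, and a step measured on one core cannot simply be carried to another, although this single square of compounds does not show why the steps differ or whether the same holds elsewhere in the series.

The compounds shown leave open whether this dependence also appears when the group on the sulfur is a plain benzyl or a longer chain such as butyl, or when the ring carbon carries an unsubstituted phenyl. They also leave open how the picture would look with a group other than 4-bromophenyl on the amide nitrogen, such as a plain phenyl or a pyridine ring.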